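Methyl on the Amine Nitrogen Across Two Chromene Cores

A few compounds are considered here, and "the series" means these few. Any claim that something is new, unique, unknown or untested is made for them only; others in the source may bear on it.

Compound 1 `COc1ccc(C(=O)c2ccc(OC)c3c2OC(C)(C)C=C3)c(NC(=O)CN)c1` and compound 2 `COc1ccc(C(=O)c2ccc(OC)c3c2C=CC(C)(C)O3)c(NC(=O)CN)c1` are built from the same atoms joined differently; how the two cores differ is not broken down here. In a functional assay on A2780 cells (Homo sapiens) for antiproliferative activity, read by MTT assay, with a stated time of 48 h (a higher number here means a weaker inhibitor, a lower number a stronger inhibitor), compound 1 gives 380 nM, and compound 2 gives 890 nM. Compound 3 `CNCC(=O)Nc1cc(OC)ccc1C(=O)c1ccc(OC)c2c1OC(C)(C)C=C2` carries, relative to compound 1, (methyl in place of hydrogen on an amine nitrogen); in this assay compound 3 gives 620 nM, so the step of a 1.6-fold higher number from compound 1 to compound 3 (0.21 log units; within the scatter). Compound 4 `CNCC(=O)Nc1cc(OC)ccc1C(=O)c1ccc(OC)c2c1C=CC(C)(C)O2` applies the same change to compound 2, namely (methyl in place of hydrogen on an amine nitrogen), at the same place. Because the step of a 1.6-fold higher number from compound 1 to compound 3 (0.21 log units; within the scatter) stayed small, a step of similar size is expected: a 1.6-fold higher number from compound 2 to compound 4 (0.20 log units; within the scatter). Compound 4 is therefore estimated at 1400 nM in this assay, with a likely range from 700 nM to 2800 nM, resting only on that single earlier step.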

Compound 4, half-maximal inhibitory concentration: 1590 nM
For compound 4 the middle estimate is 1.1-fold (0.06 log units) below the measured one, within the range that was stated.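

In this assay, methyl in place of hydrogen on the amine nitrogen gives a 1.8-fold higher number from compound 2 to compound 4 (0.25 log units; within the scatter), and this step sits close to the one seen on the other core: the same change on two cores in this assay, a 1.6-fold higher number (0.21 log units; within the scatter) from compound 1 to compound 3 and a 1.8-fold higher number (0.25 log units; within the scatter) from compound 2 to compound 4, 1.1-fold (0.04 log units) apart, within the scatter of two such steps. Across these two cores, then, the change carries over as a small step of similar size. Going by these compounds alone, that rests on only two pairs in one assay, however, and it does not show that the change would behave alike on any other core, nor why the two steps agree.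

The compounds shown leave open whether ethyl on the amine nitrogen, or a second methyl there, would give a step of similar size. Also open, as far as these compounds go, is what a longer chain in place of the aminomethyl part would do.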